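Hydroxy in place of fluoro: notes on compound 3

The source may hold more compounds than are shown below. What is called first, only, known or untested is meant among the compounds shown, and "the series" means these compounds.

In a functional assay on NCI-H157 cells (Homo sapiens) for antiproliferative activity, read by sulforhodamine B assay, with a stated time of 48 h, tested at 0.1 uM (on this read-out higher numbers stand for more inhibition of growth at the one concentration tested and lower numbers for less inhibition of growth), compound 1 (`Fc1ccc(OCc2nn3c(-c4ccncc4)nnc3s2)cc1`) gives 21.3% and stands lowest of the two measured numbers, beyond the scatter from compound 2 (`c1ccc2c(C3=Nn4c(nnc4-c4ccncc4)SC3)cccc2c1`), which gives 55.2% in the same test. Compound 3 (`Oc1ccc(OCc2nn3c(-c4ccncc4)nnc3s2)cc1`) has hydroxy in place of fluoro on an aromatic carbon, para to a large group (hydroxy in place of fluoro on an aromatic carbon). Among the measured compounds shown here, no measured pair covers this change. The expected step (a number 3.7 percentage points higher from compound 1 to compound 3 (within the scatter)) is a small rise in this assay that stays within the scatter. Compound 3 is estimated at 25% (expected range 10% to 45%).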

Compound 3, percent growth inhibition at one concentration: 52.6%
Compound 3: middle estimate off by 27.6 percentage points, on the low side; the measured number lies above the stated range.
By their numbers in this assay, from the lowest: compound 1; then compounds 3 and 2 (each within the scatter of the next).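

In this assay, among the compounds shown here, the change from 4-fluorophenyl to 4-hydroxyphenyl gives a number 31.3 percentage points higher from compound 1 to compound 3 (beyond the scatter) and is the first one-place step, showing that this site on the aromatic ring, para to a large group, responds strongly to the exchange of a single heavy atom. The entering hydroxy adds a hydrogen-bond donor and acceptor, but nothing available ties the step to either feature.

On these data alone, whether a methoxy group, an amine or a carboxylic acid at this place would give a similar step remains open. Also open, as far as these compounds go, is whether the same exchange would have a comparable effect on the other compounds.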